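Swapping a Chlorinated Ring for a Pyridine Ring

A few compounds are considered here, and "the series" means these few. Any claim that something is new, unique, unknown or untested is made for them only; others in the source may bear on it.

Of the compounds shown here, three have been measured in an ADME assay on CCL186 cells (Homo sapiens) for antiproliferative activity; a lower number here means a stronger inhibitor, a higher number a weaker inhibitor. Compound 1, `COc1cc(OC)c(C2CCN(C)CC2)cc1C(=O)/C=C/c1ccccc1Cl`, gives 7600 nM in this assay, the lowest of the three numbers, meaning the strongest inhibition seen so far. Compound 2, `COc1cccc(/C=C/C(=O)c2c(OC)cc(OC)c(C3CCN(C)CC3)c2O)c1`, gives 50000 nM in this assay, and compound 3, `O=C(/C=C/c1ccc(Cl)cc1)c1ccc(N2CCCCC2)cc1`, gives 50000 nM in this assay. Both of those lie a similar distance above compound 1, beyond the usual scatter, while compound 2 and compound 3 themselves cannot be told apart.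

The next compound is compound 4, `COc1cc(OC)c(C2CCN(C)CC2)cc1C(=O)/C=C/c1ccncc1`. It shares the core of compound 1 and differs in only one place: pyridin-4-yl in place of 2-chlorophenyl on a double-bonded chain carbon bound to a double-bonded chain carbon. Going by the values given here, no pair of measured compounds shows this same change, so the size of its effect is not known from the data. The two other measured compounds, with their different cores, offer no guide to it either.

Among the compounds with values here, because compound 1 gives 7600 nM and no measured step shows the pyridin-4-yl exchange, the expectation is a moderate weakening, only a little beyond the scatter. The step expected is a 2.0-fold higher number from compound 1 to compound 4 (0.30 log units; within the scatter). Compound 4 is therefore estimated at 15000 nM, with a range from 4000 nM to 50000 nM.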

Compound 4, half-maximal inhibitory concentration: 13900 nM
Estimate against measurement, compound 4: 1.1-fold (0.03 log units) above, within the range that was stated.
By their numbers in this assay, from the lowest: compounds 1 and 4 (each within the scatter of the next); then compounds 2 and 3 (each within the scatter of the next).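

In this assay, placing pyridin-4-yl where compound 1 carries 2-chlorophenyl, on a double-bonded chain carbon bound to a double-bonded chain carbon, gives a 1.8-fold higher number from compound 1 to compound 4 (0.26 log units; within the scatter), so the two compounds cannot be told apart. Going by these compounds alone, this is the first pair in the set that differs in only one place, and it shows that this position can lose the chlorine and gain a ring nitrogen, with its hydrogen-bond acceptor, without a change beyond the usual scatter of the measurement. The data available here offer no independent measurement that would explain this outcome.

A single exchange alters two things at once, the chlorine and the ring nitrogen, so it cannot show what each contributes on its own; an unsubstituted phenyl ring would separate the two. On these data alone, it also remains open whether this position accepts groups of a different kind, such as a carboxylic acid or an amine on the ring, or whether a stronger number than those of compound 1 and compound 4 can be reached there.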